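The compounds below may be only part of what the source reports. "The series", "measured", "known", "first", "only" and "open" are said of these compounds alone.

Three compounds have so far been measured in a functional assay on CWR22R cells (Homo sapiens) for antiproliferative activity, read by CCK-8 assay, with a stated time of 6 days; a higher number here means a weaker inhibitor, a lower number a stronger inhibitor:

Compound 1 `CCN(c1ccc(C#N)c(Cl)c1)c1cc(-c2ccncc2)ccc1C`: 1030 nM
Compound 2 `N#Cc1ccc(N2CCCc3c(-c4ccncc4)cccc32)cc1C(F)(F)F`: 15000 nM
Compound 3 `N#Cc1ccc(N2CCc3cc(-c4cnc5ccccc5c4)ccc3C2)cc1C(F)(F)F`: 25900 nM

Compound 1 has the lowest number of the three and is therefore the strongest inhibitor here; compound 2 comes nearest, with a number that sits well beyond the scatter above it, and compound 3 lies furthest off. The next compound, compound 4 `CCN(c1ccc(C#N)c(Cl)c1)c1cc(-c2cn[nH]c2)ccc1C`, keeps the core of compound 1 and changes a single group: 1H-pyrazol-4-yl in place of pyridin-4-yl on an aromatic carbon. For the measured compounds named here, no pair of measured compounds shows this particular change, so its effect cannot be read from the numbers at hand. A small step in this assay is expected, not far beyond the scatter and more likely towards a weaker inhibitor than a stronger one, giving a 1.6-fold higher number from compound 1 to compound 4 (0.19 log units; within the scatter). Compound 4 is estimated at 1600 nM, within a range from 500 nM to 5000 nM.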

Compound 4, half-maximal inhibitory concentration: > 30000 nM
Compound 4: a limit, no number (the forecaster's own chance of this, stated with the estimate: 5%); middle value at least 18-fold (1.27 log units) away from the limit.
By their numbers in this assay, from the lowest: compound 1; then compounds 2 and 3 (each within the scatter of the next). At a limit, above all of these: compound 4.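

In this assay, this position on the shared core proves sensitive to a change of ring: 1H-pyrazol-4-yl in place of pyridin-4-yl gives an at least 29-fold higher number from compound 1 to compound 4 (1.46 log units; beyond the scatter). Compound 4 gives > 30000 nM, which is a limit of the assay and not a number: the limit of > 30000 nM in this assay, at which 1 of the 4 values shown sits. The swap replaces a six-membered aromatic ring with a five-membered one and also brings in a hydrogen-bond donor, and this single step cannot separate those two differences.

From the compounds shown here alone, how a phenyl ring, a pyridin-3-yl ring or an amine would fare at this position remains open.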